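The source may report more compounds than this note shows. Statements on the series, on what has been measured and on what is new or still open speak of the compounds shown alone.

Compound 1, `CC(=O)O[C@H](CC/C(C)=C/CCc1ccc2c(c1)C(=O)C(C)=CC2=O)[C@@](C)(O)CCC=C(C)C`: 12400 nM
Compound 2, `CC(C)=CCC/C(=C/CC/C(C)=C/CC/C(C)=C/CC1=CC(=O)C(C)=CC1=O)CO`: > 48800 nM

Both compounds were tested in a functional assay on HepG2 cells (Homo sapiens) for cytotoxicity, read by MTT assay, with a stated time of 6 days; on this read-out higher numbers stand for weaker inhibition and lower numbers for stronger inhibition. Compound 1 gives a measured number, 12400 nM. For compound 2 the assay returned only a limit, > 48800 nM, so no exact number is known for it. This is the situation described by the limit of > 48800 nM in this assay, at which 1 of the 2 values shown sits.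

Compound 3, with the structure `CC(=O)OC/C(=C\CC/C(C)=C/CC/C(C)=C/CC1=CC(=O)C(C)=CC1=O)CCC=C(C)C`, has not yet been measured. Among the compounds with values here, its only difference from compound 2 is acetyl in place of hydrogen on an oxygen on a saturated carbon. Within the data shown here, no measured pair shows what this change alone does, and compound 1 is not a single-step neighbour of either compound, so its number cannot be read as a guide.

In this assay the step from compound 2 to compound 3 is therefore expected to stay within the usual scatter, as an at least 1.2-fold lower number from compound 2 to compound 3 (0.08 log units; that floor lies within the scatter). Compound 3 is estimated at 40000 nM, with a range from 15000 nM to 100000 nM, and it may well again return only a limit.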

Compound 3, half-maximal inhibitory concentration: 38100 nM
The estimate for compound 3 lay 1.0-fold (0.02 log units) above the measured number, and the stated range covers the measured number.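

Acetyl in place of hydrogen on an oxygen on a saturated carbon, hydroxymethyl to acetoxymethyl, now gives a first step for this change at this position, and in this assay it reads as an at least 1.2-fold lower number from compound 2 to compound 3 (0.10 log units; that floor lies within the scatter). Compound 2 returned only a limit, > 48800 nM. As far as these compounds go, the true size of the step stays unknown because only a floor can be stated, and that floor does not show the change to be larger than the usual scatter: the limit of > 48800 nM in this assay, at which 1 of the 3 values shown sits.

The compounds shown leave open whether a methyl ether, a longer ester such as butyryl, or an amine at this same place would give a different number. From the compounds shown here alone, whether the hydroxy to acetoxy change would give a similar step on a different core also remains open.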